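Notes on a trimethoxyphenyl swap from compound 2

The source may hold more compounds than are shown below. What is called first, only, known or untested is meant among the compounds shown, and "the series" means these compounds.

Values so far in a functional assay on HepG2 cells (Homo sapiens) for cytotoxicity, read by MTT assay, with a stated time of 24 h; on this read-out higher numbers stand for weaker inhibition and lower numbers for stronger inhibition
Compound 1 `O=C1/C(=C/c2ccccc2F)CN(S(=O)(=O)c2ccc(F)cc2)C/C1=C\c1ccccc1F` at 7220 nM
Compound 2 `CC(=O)Nc1ccc(S(=O)(=O)N2C/C(=C\c3ccccc3F)C(=O)/C(=C/c3ccccc3F)C2)cc1` at 5840 nM
Compound 3 `CC(=O)Nc1ccc(S(=O)(=O)N2C/C(=C\c3cccc([N+](=O)[O-])c3)C(=O)/C(=C/c3cccc([N+](=O)[O-])c3)C2)cc1` at 7140 nM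

Compound 2 lies within the scatter of both compound 1 and compound 3, so these values give no ranking. Compound 4 `COc1cc(/C=C2\CN(S(=O)(=O)c3ccc(NC(C)=O)cc3)C/C(=C\c3ccccc3F)C2=O)cc(OC)c1OC` differs from compound 2 by 3,4,5-trimethoxyphenyl in place of 2-fluorophenyl on a double-bonded chain carbon bound to a double-bonded ring carbon. Within the data shown here, the only measured step, a 1.2-fold lower number from compound 1 to compound 2 (0.09 log units; within the scatter), exchanges a different group and bears on this change only indirectly. Among the measured compounds shown here, no measured step covers this exchange. In this assay the expected step is a 1.1-fold lower number from compound 2 to compound 4 (0.03 log units; within the scatter), with nothing expected beyond the scatter. For compound 4 the estimate is 5500 nM, with an expected range from 2500 nM to 11000 nM.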

Compound 4, half-maximal inhibitory concentration: 4750 nM
The estimate for compound 4 lay 1.2-fold (0.06 log units) above the measured number, within the range that was stated.
By their numbers in this assay, from the lowest: compounds 4, 2, 3 and 1 (each within the scatter of the next).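

Among these compounds, the step of a 1.2-fold lower number from compound 2 to compound 4 (0.09 log units; within the scatter) in this assay is the first reading of a single aryl exchange on a double-bonded chain carbon bound to a double-bonded ring carbon. Here 3,4,5-trimethoxyphenyl, with more heavy atoms and with hydrogen-bond acceptors that 2-fluorophenyl lacks, leaves compound 4 unseparated from compound 2. Nothing available speaks to why these two compounds are so close.

Still open, as far as these compounds go, is whether an amine or a carboxylic acid on the aromatic ring at this place would give a step beyond the scatter.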